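Metabolic stability notes: from compound 3 to compound 4

The source may hold more compounds than are shown below. What is called first, only, known or untested is meant among the compounds shown, and "the series" means these compounds.

Compound 1 `CCn1ncc2c(F)cc(-c3ccc(C(CC)(CC)c4nnc(C)[nH]4)c(=O)[nH]3)cc21` and compound 2 `CCn1ncc2c(F)cc(-c3ccc(C(CC)(CC)c4ncn(C)n4)c(=O)[nH]3)cc21` share a core and differ in one group. In an ADME assay on microsomes from liver (Mus musculus) for metabolic stability (on this read-out lower numbers stand for a shorter-lived compound and higher numbers for a longer-lived compound), compound 1 returns a limit of the assay, > 3 h. In this assay compound 2 likewise returns a limit, > 3 h. The step that the two limits leave unreadable from compound 1 to compound 2 therefore cannot be sized; the limit of > 3 h in this assay, at which 2 of the 3 values shown sit, is all these two show. For the measured compounds named here, compound 3 `CC(C)C(c1ccc(-c2ccc3cccc(F)c3c2)[nH]c1=O)N1CCNC1=O` carries the only number: in this assay compound 3 gives 0.682 h. Compound 4 `CC(C)C(c1cnc(N)s1)c1ccc(-c2ccc3cccc(F)c3c2)[nH]c1=O` differs from compound 3 by 2-amino-1,3-thiazol-5-yl in place of 2-oxoimidazolidin-1-yl on a saturated chain carbon bound to an aromatic carbon and a saturated chain carbon. Going by the values given here, no measured step touches this change, and the sole recorded step is unreadable, so no shift beyond the scatter is expected in this assay in either direction. Compound 4 is accordingly expected at 0.68 h, within 0.3 h to 1.5 h. The step of a 1.0-fold lower number from compound 3 to compound 4 (0.00 log units; within the scatter) is expected to stay within scatter.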

Compound 4, half-life: 0.08 h
Estimate against measurement, compound 4: 8.5-fold (0.93 log units) above; measured number outside the range, below it.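

For the compounds shown here, the first readable step comes in this assay, which shows an 8.5-fold lower number from compound 3 to compound 4 (0.93 log units; beyond the scatter) on the saturated chain carbon bound to an aromatic carbon and a saturated chain carbon; the earlier step between limits cannot be read. This position is therefore not indifferent to the group it carries, even though 2-oxoimidazolidin-1-yl and 2-amino-1,3-thiazol-5-yl match in heavy atoms. Nothing shown gives a cause for this step.

From the compounds shown here alone, whether the step follows the amino group or the aromatic ring remains open. A plain 1,3-thiazol-5-yl or an acetamide on that ring at this position would separate the two.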